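A few compounds are considered here, and "the series" means these few. Any claim that something is new, unique, unknown or untested is made for them only; others in the source may bear on it.

Series notes, cytotoxicity. In an ADME assay on C8166 cells (Homo sapiens) for cytotoxicity, read by MTT assay, with a stated time of 3 days (on this read-out lower numbers stand for higher toxicity in this test and higher numbers for lower toxicity in this test), compound 1 `CC(C)(NC(=O)OCc1ccccc1)c1nc(O)c(O)c(C(=O)N/N=C/c2ccc(F)cc2)n1` gives 378000 nM. Compound 2 `CC(C)(NC(=O)OCc1ccccc1)c1nc(O)c(O)c(C(=O)NN)n1` reaches only the limit of this assay, > 500000 nM, which is the cut-off (the limit of > 500000 nM in this assay, at which 1 of the 3 values shown sits). Compound 3 `CC(C)(NC(=O)OCc1ccccc1)c1nc(O)c(O)c(C(=O)NCc2ccc(C(F)(F)F)cc2)n1` gives 58100 nM in this assay, the lowest of the two numbers seen; the nearest number is that of compound 1, the gap being a 6.5-fold lower number from compound 1 to compound 3 (0.81 log units; beyond the scatter), and the step of an at least 8.6-fold lower number from compound 2 to compound 3 (0.93 log units; beyond the scatter) runs in the same direction.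

Compound 4 `COc1cc(CNC(=O)c2nc(C(C)(C)NC(=O)OCc3ccccc3)nc(O)c2O)cc(OC)c1OC` differs from compound 3 by 3,4,5-trimethoxyphenyl in place of 4-(trifluoromethyl)phenyl on a saturated chain carbon bound to an amide-type nitrogen. Among the compounds with values here, no measured step exchanges one aryl group on a benzyl-type amide for another; the steps that bear on it, a 6.5-fold lower number from compound 1 to compound 3 (0.81 log units; beyond the scatter) and an at least 8.6-fold lower number from compound 2 to compound 3 (0.93 log units; beyond the scatter), both involve a change at the amide-type nitrogen itself and were modest at most. The change to compound 4 is smaller in kind, so in this assay a step within or just beyond the scatter is expected, if anything toward a higher number. For compound 4 the expected value is 110000 nM (range 40000 nM to 320000 nM), an expected step of a 1.9-fold higher number from compound 3 to compound 4 (0.28 log units; within the scatter).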

Compound 4, half-maximal cytotoxic concentration: 110000 nM
For compound 4 middle estimate and measured number coincide at the digits printed; the range from low to high includes it.
By their numbers in this assay, from the lowest: compounds 3 and 4 (each within the scatter of the next); then compound 1. At a limit, above all of these: compound 2.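

With the amide link kept, this assay now shows an exchange of the aryl group alone at this place, on a saturated chain carbon bound to an amide-type nitrogen: 3,4,5-trimethoxyphenyl in place of 4-(trifluoromethyl)phenyl gives a 1.9-fold higher number from compound 3 to compound 4 (0.28 log units; within the scatter) and so no readable change, although three hydrogen-bond acceptors enter with the new group. The steps beyond the scatter seen so far all changed the substituent on the amide-type nitrogen as a whole, and this exchange of two substituted phenyl groups does not add another. Nothing measured here gives a cause for this outcome.

Two substituted phenyl groups cannot show whether substituents on the ring matter at all, and an unsubstituted phenyl would be the direct test. As far as these compounds go, a carboxylic acid on the ring, or a longer chain to the ring, also remains open.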